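The source may report more compounds than this note shows. Statements on the series, on what has been measured and on what is new or still open speak of the compounds shown alone.

Series notes. Compound 1 `Oc1ccc(OC(=S)Nc2ccc(Sc3ccc(C(Cl)(Cl)Cl)cc3)cc2)cc1` and compound 2 `CC(=O)Nc1ccc(OC(=S)Nc2ccc(Sc3ccc(C(Cl)(Cl)Cl)cc3)cc2)cc1` share one core; compound 3 `Oc1ccc(OC(=S)Nc2ccc(Nc3ccc(C(Cl)(Cl)Cl)cc3)cc2)cc1` and the still unmeasured compound 4 `CC(=O)Nc1ccc(OC(=S)Nc2ccc(Nc3ccc(C(Cl)(Cl)Cl)cc3)cc2)cc1` share another. The difference between the two cores is not broken down here. In a physicochemical assay for lipophilicity (a lower number here means a more polar compound, a higher number a more lipophilic compound), compound 1 gives 7.43 and compound 2 gives 6.71. In this assay compound 3 gives 6.79, the second highest of the three numbers, within the scatter of compound 2 and beyond it from compound 1.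

The change from compound 1 to compound 2, (acetamido in place of hydroxy on an aromatic carbon), made the step of a number 0.72 log units lower from compound 1 to compound 2 (beyond the scatter). Among the compounds with values here, the change from compound 3 to compound 4, (acetamido in place of hydroxy on an aromatic carbon), is the same change at the same place on the same kind of ring; it is the second occurrence of this change among the four compounds, so the one measured step is the only guide. The step in this assay is expected to be about as large, a number 0.72 log units lower from compound 3 to compound 4 (beyond the scatter), because the measured step of a number 0.72 log units lower from compound 1 to compound 2 (beyond the scatter) rests on an otherwise matching pair. Compound 4 is therefore estimated at 6.07, with a likely range from 5.7 to 6.45.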

Compound 4, partition coefficient: 6.07
The estimate for compound 4 equals the measured number at the digits printed; the measured number falls inside the stated range.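

In this assay the change from 4-hydroxyphenyl to 4-acetamidophenyl gives a number 0.72 log units lower from compound 3 to compound 4 (beyond the scatter) and, on the core of compound 1, gives a number 0.72 log units lower from compound 1 to compound 2 (beyond the scatter) as well, so the change carries over between these two cores with the same size and direction. Within the data shown here, with only two matched pairs, this agreement holds for these two cores and does not establish that the step would stay the same on any other core or with the change made elsewhere on the ring. No measurement bears on the origin of the step, and the numbers record only its size and direction.

Still open, as far as these compounds go, is how this assay would read with other groups in place of hydroxy on this aromatic carbon, such as an amine, a carboxylic acid or a longer acyl chain like butyramido. Also open, from the compounds shown here alone, is whether those groups would show equal steps on both cores, as acetamido does.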